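Benzyl onto the Aromatic Oxygen of Compound 2

The compounds below may be only part of what the source reports. "The series", "measured", "known", "first", "only" and "open" are said of these compounds alone.

Compound 2 `CN1Cc2ccc(O)cc2[C@@H](OCc2ccccc2)C1` sits in an ADME assay on Vero cells (Chlorocebus sabaeus) for cytotoxicity, read by sulforhodamine B assay, with a stated time of 72 h (a higher number here means a weaker inhibitor, a lower number a stronger inhibitor), at a limit, > 50000 nM; this is a bound of the assay rather than a measured number (the limit of > 50000 nM in this assay, at which 1 of the 2 values shown sits). Compound 1 `CN1Cc2ccc(OCc3ccccc3)cc2[C@@H](O)C1` likewise reaches only a limit in this assay, > 100000 nM, which again is a bound and not a value (the limit of > 100000 nM in this assay, at which 1 of the 2 values shown sits). Among the measured compounds shown here, no step between measured compounds is given; both values are limits, so neither compound can be placed above or below the other. Compound 3 `CN1Cc2ccc(OCc3ccccc3)cc2[C@@H](OCc2ccccc2)C1` is the compound still to be measured. It differs from compound 2 by benzyl in place of hydrogen on an oxygen on an aromatic ring, so that compound 3 carries the benzyl group of compound 1 and the benzyl group of compound 2 together. With both neighbours resting at limits, no shift beyond the scatter is expected for compound 3 in this assay, and the most likely outcome is another limit. The step from compound 2 to compound 3 is accordingly expected to be a step that the limit leaves unreadable from compound 2 to compound 3. Compound 3 is estimated at 60000 nM, with a range from 20000 nM to 200000 nM.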

Compound 3, half-maximal inhibitory concentration: 23500 nM
Compound 3: middle estimate off by 2.6-fold (0.41 log units), on the high side; low and high end bracket the measured number.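

In this assay, benzyl in place of hydrogen on an oxygen on an aromatic ring gives an at least 2.1-fold lower number from compound 2 to compound 3 (0.32 log units; beyond the scatter), and benzyl in place of hydrogen on an oxygen on a saturated carbon gives an at least 4.2-fold lower number from compound 1 to compound 3 (0.62 log units; beyond the scatter), so among the compounds shown a measured number appears only where both benzyl groups stand together. Compound 1 rests at a limit, which means the step that starts from it gives only a minimum size: the limit of > 100000 nM in this assay, at which 1 of the 3 values shown sits. Compound 2 also rests at a limit, and the step that starts from it is likewise only a minimum: the limit of > 50000 nM in this assay, at which 1 of the 3 values shown sits.

From the compounds shown here alone, how much of the lower number belongs to either benzyl group alone remains open, as neither compound 1 nor compound 2 has a number to set against compound 3. Also open, going by these compounds, is whether a smaller group such as methyl on the aromatic oxygen, or a longer chain ending in an amine or a carboxylic acid, would lower the number in the same way as benzyl does.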